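A few compounds are considered here, and "the series" means these few. Any claim that something is new, unique, unknown or untested is made for them only; others in the source may bear on it.

Compound 1 `CC(C)Oc1cccc2ccc(N)nc12` carries isopropyl on the oxygen on the aromatic ring; in an assay on cells with melanin-concentrating hormone receptor 1 (Homo sapiens) as the target, read by radioligand binding (on this read-out lower numbers stand for stronger inhibition and higher numbers for weaker inhibition), compound 1 gives 437 nM, the highest of the three numbers to hand. Compound 2 `Nc1ccc2cccc(OCC3CCOC3)c2n1` gives 115 nM and compound 3 `COC(C)(C)CCOc1cccc2ccc(N)nc12` gives 132 nM. Among the measured compounds shown here, the only step beyond the scatter at that oxygen is a 3.8-fold lower number from compound 1 to compound 2 (0.58 log units; beyond the scatter); the further step a 1.1-fold higher number from compound 2 to compound 3 (0.06 log units; within the scatter) lies within the scatter. Compound 4 `CCCCOc1cccc2ccc(N)nc12` differs from compound 1 by butyl in place of isopropyl on an oxygen on an aromatic ring. Both measured replacements brought a ring or a further oxygen beyond the chain, whereas butyl brings neither, so a smaller shift toward a lower number is expected. The step is expected to be a 1.5-fold lower number from compound 1 to compound 4 (0.16 log units; within the scatter). Compound 4 is estimated at 300 nM, in the range 120 nM to 750 nM.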

Compound 4, half-maximal inhibitory concentration: 789 nM
Compound 4: middle estimate off by 2.6-fold (0.42 log units), on the low side; measured number outside the range, above it.
By their numbers in this assay, from the lowest: compounds 2 and 3 (each within the scatter of the next); then compounds 1 and 4 (each within the scatter of the next).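

In this assay, butyl and isopropyl on the oxygen are not separated (a 1.8-fold higher number from compound 1 to compound 4 (0.26 log units; within the scatter)), so this change of plain alkyl group does not reproduce the lower numbers of the other side chains. Against butyl, oxolan-3-ylmethyl and the methoxy-bearing chain both stand clearly apart (a 6.9-fold higher number from compound 2 to compound 4 (0.84 log units; beyond the scatter); a 6.0-fold higher number from compound 3 to compound 4 (0.78 log units; beyond the scatter)). Across these four compounds, the two side chains with a further oxygen give the lower numbers, and no compound goes against this.

Going by these compounds, whether that oxygen is what matters stays open, and cyclopentylmethyl, which keeps a ring without it, would test this. No data on why these numbers differ are at hand.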